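This account rests on a few compounds, and the source may have more. Where it says the series, first, only, none or still open, it means among the compounds named here.

All numbers here come from an ADME assay on MT4 cells (Homo sapiens) for cytotoxicity, read by MTT assay, with a stated time of 4 days (on this read-out lower numbers stand for higher toxicity in this test and higher numbers for lower toxicity in this test), and no other test. Compound 3 (`C/C(=N\NC(=O)COc1cccc2ccccc12)c1ccc(Br)cc1`) gives 77.6 ug/mL and stands within the scatter of compound 2 (`C/C(=N\NC(=O)COc1cccc2ccccc12)c1ccccc1`) at 105 ug/mL on this read-out. Compound 1 (`C/C(=N\NC(=O)COc1cccc2ccccc12)c1cccc([N+](=O)[O-])c1`) gives 12.1 ug/mL as the lowest number of the three, beyond the scatter from both others.

Compound 4 (`C/C(=N\NC(=O)COc1cccc2ccccc12)c1ccc(O)cc1`) carries hydroxy in place of bromo on an aromatic carbon, para to a large group (hydroxy in place of bromo on an aromatic carbon). Going by the values given here, no measured compound carries hydroxy, so no step tests this change directly. The closest evidence is a 1.4-fold lower number from compound 2 to compound 3 (0.13 log units; within the scatter) for bromo in place of hydrogen at the same place. The steps of an 8.7-fold higher number from compound 1 to compound 2 (0.94 log units; beyond the scatter) and a 6.4-fold higher number from compound 1 to compound 3 (0.81 log units; beyond the scatter) are larger, but both start from the 3-nitrophenyl compound and bear only loosely on this change. With a 1.4-fold lower number from compound 2 to compound 3 (0.13 log units; within the scatter) as the main guide, no step beyond the scatter is expected in this assay for this change. The estimated step is a 1.1-fold lower number from compound 3 to compound 4 (0.04 log units; within the scatter) with wide uncertainty. For compound 4 the estimated value is 70 ug/mL with an expected range from 25 ug/mL to 180 ug/mL on this read-out.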

Compound 4, half-maximal cytotoxic concentration: 68.8 ug/mL
Compound 4: the middle estimate sits 1.0-fold (0.01 log units) above what was measured; low and high end bracket the measured number.
By their numbers in this assay, from the lowest: compound 1; then compounds 4, 3 and 2 (each within the scatter of the next).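

In this assay, this place on the aromatic ring, para to a large group, now tolerates a second kind of exchange: hydroxy, a hydrogen-bond donor and acceptor, replaces bromo with a 1.1-fold lower number from compound 3 to compound 4 (0.05 log units; within the scatter), and it replaces hydrogen with a 1.5-fold lower number from compound 2 to compound 4 (0.18 log units; within the scatter). Hydrogen, bromo and hydroxy at this place therefore cannot be told apart on this read-out, while a 5.7-fold higher number from compound 1 to compound 4 (0.75 log units; beyond the scatter) leaves compound 1 as the only compound beyond the scatter from all the others. No measurement shown here offers an explanation for this flat response.

On these data alone, whether an amine, a carboxylic acid or a longer chain at this place would also stay within the scatter remains open. Also open, as far as these compounds go, is whether the low number of compound 1 goes with the nitro group itself or with its 3-nitrophenyl arrangement, which a 4-nitrophenyl analogue would help to separate.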